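Pyridine ether replacement in the propanamide series

The source may report more compounds than this note shows. Statements on the series, on what has been measured and on what is new or still open speak of the compounds shown alone.

Compound 1 `CC(C(=O)NCc1ccc(C(C)(C)C)nc1OC1CCCC1)c1ccc(NS(C)(=O)=O)c(F)c1` gives 1.5 nM in an assay on cells for antagonist activity at transient receptor potential cation channel subfamily V member 1 (Homo sapiens), read by FLIPR and calcium flux, with a stated time of 6 min (a higher number here means a weaker inhibitor, a lower number a stronger inhibitor), and compound 2 `CCOCCOc1nc(C(C)(C)C)ccc1CNC(=O)C(C)c1ccc(NS(C)(=O)=O)c(F)c1` gives 23.9 nM. Among the compounds with values here, the only measured step is a 16-fold higher number from compound 1 to compound 2 (1.20 log units; beyond the scatter), so compound 2 stands at the weaker end of the two numbers known. Compound 3 `CC(C(=O)NCc1ccc(C(C)(C)C)nc1SCCCN1CCCC1)c1ccc(NS(C)(=O)=O)c(F)c1` carries (3-(pyrrolidin-1-yl)propyl)sulfanyl in place of 2-ethoxyethoxy on an aromatic carbon. Within the data shown here, no measured step bears directly on a sulfur-linked group at this position; the single step from compound 1 to compound 2 shows that a flexible chain on the ring oxygen gives a weaker number than cyclopentyl, and compound 3 again carries a flexible chain at the same place. The step from compound 2 to compound 3 is therefore expected to stay within the scatter, with wide uncertainty, as a 1.0-fold higher number from compound 2 to compound 3 (0.02 log units; within the scatter). Compound 3 is estimated at 25 nM in this assay, within the range 5 nM to 125 nM.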

Compound 3, inhibition constant: 17.1 nM
Beside the measured number, compound 3's estimate is 1.5-fold (0.16 log units) above it; the range from low to high includes it.
By their numbers in this assay, from the lowest: compound 1; then compounds 3 and 2 (each within the scatter of the next).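

In this assay, the change on this aromatic carbon next to the ring nitrogen gives a 1.4-fold lower number from compound 2 to compound 3 (0.15 log units; within the scatter), so replacing 2-ethoxyethoxy with (3-(pyrrolidin-1-yl)propyl)sulfanyl, which swaps the linking oxygen for sulfur and adds a five-membered non-aromatic ring, does not separate the two compounds. Cyclopentyloxy stays apart with an 11-fold higher number from compound 1 to compound 3 (1.06 log units; beyond the scatter), and compound 1 now stands beyond the scatter from both chain-bearing compounds, compound 2 and compound 3. No supporting evidence is available to explain these differences.

The sulfur link and the pyrrolidine ring change together, so a 3-(pyrrolidin-1-yl)propoxy or cyclopentylsulfanyl group would be needed to tell them apart. As far as these compounds go, it also remains open whether other rings on the linking oxygen match cyclopentyloxy, such as cyclohexyloxy or piperidin-4-yloxy.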